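A few compounds are considered here, and "the series" means these few. Any claim that something is new, unique, unknown or untested is made for them only; others in the source may bear on it.

Measured in a functional assay for inhibition, with Rattus norvegicus as the target; on this read-out lower numbers stand for stronger inhibition and higher numbers for weaker inhibition:
- compound 2 `CCC(C)(C)/N=c1\c(O)c(O)\c1=N/Cc1c(C)cc(C)cc1Cl` gives 200 nM
- compound 1 `CC(C)(C)/N=c1\c(O)c(O)\c1=N/Cc1ccc(F)cc1` gives 1500 nM
- compound 3 `CCC(C)(C)/N=c1\c(O)c(O)\c1=N/Cc1c(C)cccc1Cl` gives 4400 nM

Compound 2 stands lowest of the three numbers in this assay; compound 1 lies nearest and compound 3 furthest. Going by the values given here, the only single-point step is a 22-fold higher number from compound 2 to compound 3 (1.34 log units; beyond the scatter), a loss on removing one methyl from the benzylic ring. Compound 4 `CCC(C)(C)/N=c1\c(O)c(O)\c1=N/Cc1c(C)cc(C)cc1C` differs from compound 2 by methyl in place of chloro on an aromatic carbon. Among the compounds with values here, no measured step exchanges chloro for methyl, so the change is untested; both groups are of one heavy atom and the methyl count that separated compound 2 from compound 3 is kept, so in this assay only a small shift, likely within the scatter, is expected. Compound 4 is estimated at 300 nM (range 110 nM to 850 nM), a step of a 1.5-fold higher number from compound 2 to compound 4 (0.18 log units; within the scatter).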

Compound 4, half-maximal inhibitory concentration: 310 nM
The estimate for compound 4 lay 1.0-fold (0.01 log units) below the measured number, and the stated range covers the measured number.
By their numbers in this assay, from the lowest: compounds 2 and 4 (each within the scatter of the next); then compound 1; then compound 3.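

In this assay, the exchange of chloro for methyl at this aromatic carbon, ortho to a large group, gives a 1.6-fold higher number from compound 2 to compound 4 (0.19 log units; within the scatter), so the two groups cannot be told apart at this position in this pair. This single-atom exchange contrasts with a 22-fold higher number from compound 2 to compound 3 (1.34 log units; beyond the scatter), where hydrogen replaces a methyl on the same ring. Nothing at hand gives a reason for this result.

On these data alone, whether a longer group here, such as ethyl or methoxy, would keep the number in this range stays open. Also open, as far as these compounds go, is whether chloro and methyl still match on a ring carrying fewer methyl groups.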